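The source may hold more compounds than are shown below. What is called first, only, known or untested is meant among the compounds shown, and "the series" means these compounds.

In a functional assay on MT2 cells (Homo sapiens) for antiproliferative activity, read by MTT assay, with a stated time of 72 h (a higher number here means a weaker inhibitor of growth, a lower number a stronger inhibitor of growth), compound 1 `O=C(COc1ccc2oc(-c3ccccc3)cc(=O)c2c1)Nc1ccc2ccccc2c1` gives > 10000 nM, which is a limit of the assay and not a number. Compound 2 `COc1ccc(NC(=O)COc2c(-c3ccccc3)oc3ccccc3c2=O)cc1` gives > 10000 nM, which is also a limit. Measurements so far therefore amount to the limit of > 10000 nM in this assay, at which 2 of the 2 values shown sit, and neither compound has a numerical value that could anchor a comparison.

Compound 3 `O=C(COc1ccc2oc(-c3ccccc3)cc(=O)c2c1)Nc1ccc(F)cc1` keeps the core of compound 1 and changes one group: it has 4-fluorophenyl in place of naphthalen-2-yl on an amide-type nitrogen. Among the compounds with values here, no measured pair of compounds shows what a change of this kind does in this assay, so there is no precedent for the size of the step. The expectation rests on compound 1, whose > 10000 nM is a limit, and it stays close to that limit. The expected step of a number no higher from compound 1 to compound 3 (the limit leaves the size open) is estimated to be no larger than the usual scatter, with no favoured direction, and compound 3 may well return only a limit too. The estimate for compound 3 is 10000 nM, with an expected range of 3000 nM to 30000 nM.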

Compound 3, concentration for 50% growth inhibition: 470 nM
Estimate against measurement, compound 3: 21-fold (1.33 log units) above; the whole stated range lies above it.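

Within the data shown here, compound 3 gives the first real number in this assay, showing that the shared core can carry growth inhibition on these cells with a suitable group on the amide-type nitrogen. Placing 4-fluorophenyl there in place of naphthalen-2-yl gives an at least 21-fold lower number from compound 1 to compound 3 (1.32 log units; beyond the scatter), so in this pair the group on that nitrogen decides whether a number can be read at all. Compound 1 stands at a limit and not at a number, which leaves the true size of the step open, and limits still make up most of the data: the limit of > 10000 nM in this assay, at which 2 of the 3 values shown sit.

The change swaps two aromatic rings for one and brings in fluorine in the same move, so these compounds cannot say whether the smaller ring system or the fluorine carries the gain. A plain phenyl on the same nitrogen would begin to separate the two, and a phenyl ring carrying an amine or a carboxylic acid would show how much variation this place tolerates.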